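Amide nitrogen substituents and cytotoxicity: cyclopropyl to isopentyl

The source may hold more compounds than are shown below. What is called first, only, known or untested is meant among the compounds shown, and "the series" means these compounds.

Working notes on the series, read in an ADME assay on HEK-293T cells (Homo sapiens) for cytotoxicity, read by luminescence, with a stated time of 24 h; on this read-out higher numbers stand for lower toxicity in this test and lower numbers for higher toxicity in this test. Compound 1 `COc1ccc(Cn2c(C(=O)N3CCC(C(N)=O)CC3)cc3sccc32)cc1` gives > 100000 nM, which is a limit of the assay and not a number. For the measured compounds named here, compound 2 `COc1ccc(Cn2c(C(=O)N3CCC(C(=O)NC4CC4)CC3)cc3sccc32)cc1` gives 21400 nM, the only true number so far in this assay.

The next structure, compound 3 `COc1ccc(Cn2c(C(=O)N3CCC(C(=O)NCCC(C)C)CC3)cc3sccc32)cc1`, has isopentyl in place of cyclopropyl on an amide-type nitrogen. The core and the rest of the amide are unchanged.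

Going by the values given here, one measured step bears on this nitrogen: an at least 4.6-fold lower number from compound 1 to compound 2 (0.66 log units; beyond the scatter). There, cyclopropyl replaced hydrogen and the number fell. The new change puts a larger carbon group at the same place, so a further small fall is expected, though a single step is thin ground for this. The expected move is a 1.8-fold lower number from compound 2 to compound 3 (0.25 log units; within the scatter), which may well stay within the scatter. A return to the limit seen for compound 1 is considered unlikely but is not excluded.

For compound 3 the estimate is 12000 nM, with an expected range of 4500 nM to 40000 nM.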

Compound 3, half-maximal cytotoxic concentration: 30900 nM
For compound 3 the middle estimate is 2.6-fold (0.41 log units) below the measured one; low and high end bracket the measured number.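

In this assay, isopentyl in place of cyclopropyl on the amide-type nitrogen gives a 1.4-fold higher number from compound 2 to compound 3 (0.16 log units; within the scatter), so an open branched chain and a three-membered ring cannot be told apart at this place. Isopentyl in place of hydrogen on the same nitrogen gives an at least 3.2-fold lower number from compound 1 to compound 3 (0.51 log units; beyond the scatter), which adds a second carbon group to the one earlier step of this kind, and both steps are beyond the scatter. For these three compounds, the difference in this assay therefore lies between the amide hydrogen and a carbon group on the nitrogen, not between the two carbon groups, although the larger group and the loss of the ring were both new to this comparison.

From the compounds shown here alone, the value of compound 1 is a limit of the assay and not a number, so the full size of both steps from compound 1 stays open: the limit of > 100000 nM in this assay, at which 1 of the 3 values shown sits. Also open is whether a longer chain, a terminal amine or a carboxylic acid on this nitrogen would stay level with compound 2 and compound 3 or move beyond the scatter.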